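A Ring Substituent Swap on a Cytotoxic Enone Ester

The source may report more compounds than this note shows. Statements on the series, on what has been measured and on what is new or still open speak of the compounds shown alone.

Compound 1 `CCCCCCCC/C=C\CCCCCCCC(=O)OC[C@H]1O[C@H](CC2=CCCCC2)C=CC1=O`: 80 nM
Compound 2 `CC/C=C\C/C=C\C/C=C\C/C=C\C/C=C\C/C=C\CCC(=O)OC[C@@H]1C=CC(=O)[C@@H](C2CCCC=C2C)O1`: 65000 nM

In a functional assay on LFCl2A cells (Rattus norvegicus) for cytotoxicity (on this read-out higher numbers stand for weaker inhibition and lower numbers for stronger inhibition), compound 1 gives 80 nM, the lowest of the two numbers. Compound 2 gives 65000 nM, a far higher number, well beyond the scatter; yet compound 2 differs from compound 1 in several places at once, so no single step can be read from that pair. Compound 3 `CCCCCCCC/C=C\CCCCCCCC(=O)OC[C@H]1O[C@H](C2CCCC=C2C)C=CC1=O` has not yet been measured in this assay. It differs from compound 1 in one place only: 2-methylcyclohex-2-en-1-yl in place of (cyclohex-1-en-1-yl)methyl on a saturated ring carbon. Going by the values given here, the ring group that enters is the one carried by compound 2, whose result in this assay is the weak 65000 nM, though other parts of compound 2 also differ. On that basis a loss of potency is expected, of moderate size: a 5.0-fold higher number from compound 1 to compound 3 (0.70 log units; beyond the scatter). Compound 3 is therefore estimated at 400 nM, with a range from 60 nM to 5000 nM.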

Compound 3, half-maximal inhibitory concentration: 50 nM
For compound 3 the middle estimate is 8.0-fold (0.90 log units) above the measured one; the whole stated range lies above it.
By their numbers in this assay, from the lowest: compounds 3 and 1 (each within the scatter of the next); then compound 2.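

In this assay, putting 2-methylcyclohex-2-en-1-yl in place of (cyclohex-1-en-1-yl)methyl on this saturated ring carbon, next to the ring oxygen, gives a 1.6-fold lower number from compound 1 to compound 3 (0.20 log units; within the scatter), so the two groups cannot be told apart on this read-out. Compound 3 carries the same ring group as compound 2 yet stays in the range of compound 1, so the high number of compound 2, 65000 nM, cannot be laid on that ring group alone. Nothing measured here explains why the two groups read alike.

Which of the other differences in compound 2, such as its ester chain, accounts for its number remains open. So does whether this position would accept a group of another kind, such as an amine or a carboxylic acid, with the number unchanged.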